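This account rests on a few compounds, and the source may have more. Where it says the series, first, only, none or still open, it means among the compounds named here.

The compounds share one core, to which an amide bearing a varied group is attached. Compound 1 `CC(C)n1ncc2c(C(=O)Nc3ccccc3)cccc21` carries a phenyl on the amide nitrogen, and in a functional assay on HepG2 cells (Homo sapiens) for inhibition, read by MTT assay, with a stated time of 72 h (on this read-out higher numbers stand for weaker inhibition and lower numbers for stronger inhibition), compound 1 gives 23700 nM. Compound 2 `CC(C)n1ncc2c(C(=O)NC3CCCC3)cccc21` carries a cyclopentyl there instead. In this assay compound 2 reaches only a limit of the assay, > 40000 nM. The step of an at least 1.6-fold higher number from compound 1 to compound 2 (0.22 log units; that floor lies within the scatter) is therefore known only as a floor. Compound 3 `CC(C)n1ncc2c(C(=O)NCc3cn(-c4ccc(F)cc4)nn3)cccc21` links the amide nitrogen through a longer arm to a five-membered aromatic ring with three nitrogens, which bears a 4-fluorophenyl. In this assay compound 3 also gives only a limit of the assay, > 40000 nM, so no number is known for it. Two of the three values sit at the same point: the limit of > 40000 nM in this assay, at which 2 of the 3 values shown sit.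

Compound 4 `CC(C)n1ncc2c(C(=O)NCc3cn(-c4ccccc4F)nn3)cccc21` differs from compound 3 in one place: 2-fluorophenyl in place of 4-fluorophenyl on an aromatic nitrogen. For the measured compounds named here, no measured step touches a fluorine on a ring; the only measured step swaps the whole group on the amide nitrogen. With nothing to point the other way, the step that the limit leaves unreadable from compound 3 to compound 4 is expected to stay within the scatter. Compound 4 is thus estimated at 45000 nM, between 15000 nM and 120000 nM, and most likely reported only as a limit.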

Compound 4, half-maximal inhibitory concentration: > 40000 nM
Compound 4 gave a limit, no number (the forecaster's own chance of this, stated with the estimate: 80%); the middle value does not contradict the limit.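

In this assay compound 4 gives > 40000 nM, which is a limit of the assay and not a number. For the compounds shown here, compound 3 also gives only a limit, so no step between compound 3 and compound 4 can be read. The values now gather at one point: the limit of > 40000 nM in this assay, at which 3 of the 4 values shown sit. The compounds shown leave open whether 2-fluorophenyl and 4-fluorophenyl differ at all in this assay.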